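The compounds below may be only part of what the source reports. "The series", "measured", "known", "first", "only" and "open" are said of these compounds alone.

Of the compounds shown here, two built on a shared core have been tested in a toxicity assay on J774.A1 cells (Mus musculus) for cytotoxicity, read by SYBR Green assay, with a stated time of 1 h; on this read-out lower numbers stand for an effect already at smaller amounts and higher numbers for an effect only at larger amounts of compound. Compound 1 `CN(C)c1ccc2cc(-c3cn(C)c4ccccc34)c(N)nc2c1` gives 3700 nM there. Compound 2 `CN(C)c1ccc2cc(-c3coc4ccccc34)c(N)nc2c1` gives 5100 nM in this assay, and the two numbers lie within the usual scatter of each other, so neither stands apart. Compound 3 `CNc1ccc2cc(-c3cn(C)c4ccccc34)c(N)nc2c1` differs from compound 1 in one place: hydrogen in place of methyl on a nitrogen on an aromatic ring. Among the measured compounds shown here, no pair of measured compounds shows this change, so only a small step is expected in this assay, in no firm direction. The step of a 1.1-fold higher number from compound 1 to compound 3 (0.03 log units; within the scatter) is therefore expected to stay within the scatter. Compound 3 is estimated at 4000 nM, with a range from 1500 nM to 10000 nM.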

Compound 3, half-maximal effective concentration: 4100 nM
Beside the measured number, compound 3's estimate is 1.0-fold (0.01 log units) below it; low and high end bracket the measured number.
By their numbers in this assay, from the lowest: compounds 1, 3 and 2 (each within the scatter of the next).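

Hydrogen in place of methyl on a nitrogen on an aromatic ring gives a 1.1-fold higher number from compound 1 to compound 3 (0.04 log units; within the scatter) in this assay and so stays within the scatter. Among the compounds shown here, this is the first direct reading at this position: going from dimethylamino to methylamino does not separate the two compounds here. No available evidence accounts for this result.

Still open, going by these compounds, is whether a longer chain, such as ethyl, or a ring such as morpholine at this position would leave the number equally undisturbed. On these data alone, it is also open whether the same change would behave alike in compound 2.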